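The source may hold more compounds than are shown below. What is called first, only, known or untested is meant among the compounds shown, and "the series" means these compounds.

Measured compounds in a functional assay on A549 cells (Homo sapiens) for antiproliferative activity, read by MTT assay, with a stated time of 24 h; on this read-out lower numbers stand for stronger inhibition and higher numbers for weaker inhibition:
- compound 1, `Cc1cccc(-n2cc(-c3ccccc3NS(=O)(=O)c3c[nH]c(=O)[nH]c3=O)nn2)c1`: 1870 nM
- compound 2, `O=c1[nH]cc(S(=O)(=O)Nc2ccccc2-c2cn(-c3ccc(F)cc3)nn2)c(=O)[nH]1`: 6390 nM
- compound 3, `Cc1ccccc1-n1cc(-c2cccc(NS(=O)(=O)c3c[nH]c(=O)[nH]c3=O)c2)nn1`: 5470 nM

Compound 3 stands second highest of the three numbers in this assay. Its nearest neighbour is compound 2, whose number is within the scatter of that of compound 3, so no order between the two can be read. Compound 1 is the furthest away, with a number beyond the scatter below that of compound 3.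

For the measured compounds named here, the one step that can be computed among the measured compounds, a 3.4-fold higher number from compound 1 to compound 2 (0.53 log units; beyond the scatter), changes the group on the aromatic nitrogen, 4-fluorophenyl in place of 3-methylphenyl, within a pair whose sulfonamide sits on the shared core differently from compound 3.

Compound 4, `Cc1ccc(-n2cc(-c3cccc(NS(=O)(=O)c4c[nH]c(=O)[nH]c4=O)c3)nn2)cc1`, is not yet measured. It differs from compound 3 by 4-methylphenyl in place of 2-methylphenyl on an aromatic nitrogen. Going by the values given here, no measured step moves the methyl from one position to another on the same aryl group; the step from compound 1 to compound 2 changes both the group and its position and does not bear directly on this one. The expectation is therefore a change of no more than the scatter in this assay, in either direction.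

Compound 4 is estimated at 5000 nM, range 2500 nM to 11000 nM, which corresponds to the expected step of a 1.1-fold lower number from compound 3 to compound 4 (0.04 log units; within the scatter).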

Compound 4, half-maximal inhibitory concentration: 3630 nM
The estimate for compound 4 lay 1.4-fold (0.14 log units) above the measured number; the range from low to high includes it.
By their numbers in this assay, from the lowest: compounds 1, 4, 3 and 2 (each within the scatter of the next, the first and the last beyond it).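

In this assay, 4-methylphenyl in place of 2-methylphenyl on the aromatic nitrogen gives a 1.5-fold lower number from compound 3 to compound 4 (0.18 log units; within the scatter). For the compounds shown here, this is the first step that keeps the same atoms in the group on this nitrogen and changes only where the methyl sits, whereas the earlier step from compound 1 to compound 2 changed the substituent and its place together. On the core of compound 3, these two methyl placements therefore cannot be told apart in this assay, and no order can be read between the two compounds. No measurement at hand bears on the reason for this result.

Still open, from the compounds shown here alone, is whether a different kind of group on this nitrogen, such as a benzyl group, a short alkyl chain or a phenyl ring carrying an amine or a carboxylic acid, would shift the number beyond the scatter on this core. Also open is whether 2-methylphenyl and 4-methylphenyl would stay as close on the core of compound 1, where only 3-methylphenyl and 4-fluorophenyl are shown.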